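From a Phenol to a Trifluoromethyl Analogue: Compound 4

The source may hold more compounds than are shown below. What is called first, only, known or untested is meant among the compounds shown, and "the series" means these compounds.

Measured so far in a functional assay on DU-145 cells (Homo sapiens) for cytotoxicity; a lower number here means a stronger inhibitor of growth, a higher number a weaker inhibitor of growth:
compound 1, `OCCCCC#Cc1ccccc1C#Cc1ccccc1`, gives 5220 nM
compound 2, `OCCCCC#Cc1ccccc1C#Cc1cccs1`, gives 13000 nM
compound 3, `OCCCCC#Cc1ccccc1C#Cc1ccc(O)cc1`, gives 16800 nM

Compound 3 carries the highest number of the three; its gap to compound 2 lies within the scatter, while compound 1 sits clearly lower. Compound 4, `OCCCCC#Cc1ccccc1C#Cc1ccc(C(F)(F)F)cc1`, differs from compound 3 by trifluoromethyl in place of hydroxy on an aromatic carbon. For the measured compounds named here, the one step that bears on this change is the one from compound 1 to compound 3, a 3.2-fold higher number from compound 1 to compound 3 (0.51 log units; beyond the scatter), where hydroxy entered at that same place; compound 4 removes that hydroxy again and adds trifluoromethyl, for which no step exists. A modest move back toward compound 1 is therefore expected for compound 4, a 2.8-fold lower number from compound 3 to compound 4 (0.45 log units; beyond the scatter). The estimate for compound 4 in this assay is 6000 nM, expected between 2500 nM and 15000 nM.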

Compound 4, concentration for 50% growth inhibition: 15800 nM
The estimate for compound 4 lay 2.6-fold (0.42 log units) below the measured number; measured number outside the range, above it.
By their numbers in this assay, from the lowest: compound 1; then compounds 2, 4 and 3 (each within the scatter of the next).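

In this assay, for the compounds shown here, the earlier compounds tied a higher number at this place only to hydroxy (a 3.2-fold higher number from compound 1 to compound 3 (0.51 log units; beyond the scatter)). Compound 4 shows that trifluoromethyl, with 0 hydrogen-bond donors and 0 hydrogen-bond acceptors, also gives a higher number than hydrogen (a 3.0-fold higher number from compound 1 to compound 4 (0.48 log units; beyond the scatter)). Exchanging hydroxy for trifluoromethyl leaves the result within the scatter (a 1.1-fold lower number from compound 3 to compound 4 (0.03 log units; within the scatter)), so the hydrogen-bond donor of hydroxy is not needed for this result. From the compounds shown here alone, whether an amine, a carboxylic acid or a single fluorine at this place would behave alike remains open. No measured evidence here accounts for these numbers.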